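The source may hold more compounds than are shown below. What is called first, only, known or untested is meant among the compounds shown, and "the series" means these compounds.

In a functional assay on HCT-116 cells (Homo sapiens) for inhibition (a higher number here means a weaker inhibitor, a lower number a stronger inhibitor), compound 1 (`CCNC(=O)c1noc(-c2cc(C(C)C)c(O)cc2O)c1-c1cc(CO)no1`) gives 13 nM, while compound 2 (`CCNC(=O)c1noc(-c2cc(C(C)C)c(O)cc2O)c1-c1cc(CNCCO)no1`) gives 111 nM, the higher and therefore weaker of the two results so far. Among the measured compounds shown here, compound 3 (`CCNC(=O)c1noc(-c2cc(C(C)C)c(O)cc2O)c1-c1cc(CN2CCN(C)CC2)no1`) keeps the shared core of compound 2 and changes only one group: 4-methylpiperazin-1-yl in place of (2-hydroxyethyl)amino on a saturated chain carbon bound to an aromatic carbon. In words, 4-methylpiperazin-1-yl stands in place of (2-hydroxyethyl)amino on a saturated chain carbon bound to an aromatic carbon.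

For the measured compounds named here, only one measured step bears on this change. It is an 8.5-fold higher number from compound 1 to compound 2 (0.93 log units; beyond the scatter), a modest step beyond the scatter, seen when (2-hydroxyethyl)amino replaced hydroxy on that same carbon. This shows that the result can move with the group at this place, but it is a single pair. Neither measured compound carries 4-methylpiperazin-1-yl, so the data give no direct measure of the new swap. Both the leaving and the entering group are attached through nitrogen, so no clear direction can be argued, and any shift is expected to be small.

The expected step is a 1.1-fold lower number from compound 2 to compound 3 (0.05 log units; within the scatter), which is probably within the scatter. For compound 3 the estimated value is 100 nM, with an expected range from 30 nM to 330 nM.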

Compound 3, half-maximal inhibitory concentration: 340 nM
Estimate against measurement, compound 3: 3.4-fold (0.53 log units) below; measured number above the stated range.
By their numbers in this assay, from the lowest: compound 1; then compound 2; then compound 3.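

In this assay the group on this saturated chain carbon matters even between two groups attached through nitrogen: changing (2-hydroxyethyl)amino to 4-methylpiperazin-1-yl gives a 3.1-fold higher number from compound 2 to compound 3 (0.49 log units; beyond the scatter) and so makes a weaker inhibitor. Measured against hydroxy, the same group gives a 26-fold higher number from compound 1 to compound 3 (1.42 log units; beyond the scatter) and this larger step shows that, among these three compounds, the hydroxy of compound 1 gives the strongest inhibitor and the 4-methylpiperazin-1-yl of compound 3 the weakest. The new group differs from (2-hydroxyethyl)amino in carrying a ring and no hydrogen-bond donors, but no measurement shown ties the higher number to either feature.

Still open, on these data alone, is whether the ring or its methyl group goes with the higher number, a question that piperazin-1-yl without the methyl or a morpholin-4-yl group on the same carbon could help to settle. Also open, as far as these compounds go, is how a methoxy group or a carboxylic acid at this place would compare with hydroxy, and whether the same order holds on another core.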